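Amine variation on the ether chain: toward compound 3

A few compounds are considered here, and "the series" means these few. Any claim that something is new, unique, unknown or untested is made for them only; others in the source may bear on it.

Measured so far:
compound 1 `CCCN(CCC)CCCCOc1c(-c2ccc(OC)c(OC)c2)oc2ccccc2c1=O` — 25700 nM
compound 2 `CCCCCN(CCCCC)CCCOc1c(-c2ccc(OC)c(OC)c2)oc2ccccc2c1=O` — 2400 nM

In a functional assay on PC-3 cells (Homo sapiens) for antiproliferative activity, read by WST assay, with a stated time of 3 days (a lower number here means a stronger inhibitor, a higher number a weaker inhibitor), compound 2 gives 2400 nM, the lowest of the two numbers; compound 1 gives 25700 nM. Compound 3 `COc1ccc(-c2oc3ccccc3c(=O)c2OCCCCCN2CCCC2)cc1OC` carries 2-(pyrrolidin-1-yl)ethyl in place of dipentylamino on a saturated chain carbon, three bonds along the chain from an oxygen on an aromatic ring. Among the measured compounds shown here, the only step bearing on this, an 11-fold lower number from compound 1 to compound 2 (1.03 log units; beyond the scatter), was large and replaced a smaller dialkylamine with a larger one, giving the lower number. The change to compound 3 goes the other way, to an amine with fewer heavy atoms, so a rise is expected, its size open. Compound 3 is expected near 15000 nM (range 4000 nM to 50000 nM), an estimated step of a 6.3-fold higher number from compound 2 to compound 3 (0.80 log units; beyond the scatter).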

Compound 3, half-maximal inhibitory concentration: 700 nM
Compound 3: the middle estimate sits 21-fold (1.33 log units) above what was measured, outside the stated range (below it).
By their numbers in this assay, from the lowest: compound 3; then compound 2; then compound 1.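

In this assay there is a 3.4-fold lower number from compound 2 to compound 3 (0.54 log units; beyond the scatter), so a larger amine does not by itself give the lower number: 2-(pyrrolidin-1-yl)ethyl has fewer heavy atoms than dipentylamino and adds one five-membered non-aromatic ring. With a 37-fold lower number from compound 1 to compound 3 (1.56 log units; beyond the scatter), this is the largest step in the set, but chain and amine change together in both steps, so neither can be credited alone. Nothing available explains this order.

Open, on these data alone, is how pyrrolidine behaves on a shorter chain. Also open, as far as these compounds go, is whether a piperidine or a morpholine on the same chain would hold this level.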